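Moving the Fluorine on the Urea Aryl Ring

The compounds below may be only part of what the source reports. "The series", "measured", "known", "first", "only" and "open" are said of these compounds alone.

Measured so far:
Compound 2, `CCOC(=O)c1cnn2c1N(C(=O)Nc1cccc(F)c1)C(c1ccccc1)C2`: 9.2 nM
Compound 1, `O=C(Nc1ccc(F)cc1)N1c2ccnn2CC1c1ccccc1`: 95 nM

In a functional assay on cells (Neutrophil, Homo sapiens) for inhibition, with a stated time of 10 min (on this read-out lower numbers stand for stronger inhibition and higher numbers for weaker inhibition), compound 2 gives 9.2 nM, the lowest number of the two measured compounds. Compound 1 gives 95 nM in this assay, a gap beyond the usual scatter. Compound 3, `CCOC(=O)c1cnn2c1N(C(=O)Nc1ccc(F)cc1)C(c1ccccc1)C2`, is not yet measured and differs from compound 2 only in 4-fluorophenyl in place of 3-fluorophenyl on an amide-type nitrogen. Among the compounds with values here, compound 1 also carries a 4-fluorophenyl, but it differs from compound 2 in more than one place, so no single measured step covers this change. Only a small step is expected, a 1.6-fold higher number from compound 2 to compound 3 (0.21 log units; within the scatter), within the scatter or slightly towards weaker inhibition. Compound 3 is estimated at 15 nM, with a range from 5 nM to 45 nM.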

Compound 3, half-maximal inhibitory concentration: 10.3 nM
Beside the measured number, compound 3's estimate is 1.5-fold (0.16 log units) above it; the measured number falls inside the stated range.
By their numbers in this assay, from the lowest: compounds 2 and 3 (each within the scatter of the next); then compound 1.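

In this assay, moving the fluorine gives a 1.1-fold higher number from compound 2 to compound 3 (0.05 log units; within the scatter) and so makes no measurable difference on this amide-type nitrogen's aryl ring. Within the data shown here, compound 3 also forms the first single-change pair with compound 1, giving a 9.2-fold lower number from compound 1 to compound 3 (0.96 log units; beyond the scatter) for ethoxycarbonyl in place of hydrogen on an aromatic carbon. The gap between the earlier compounds therefore follows the ethoxycarbonyl, not the fluorine position, though no measured evidence here explains either result.

Still open, going by these compounds, is whether chlorine or methoxy in place of the fluorine would behave the same way. Also open, on these data alone, is whether a carboxylic acid in place of the ethoxycarbonyl would retain this inhibition.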